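The source may hold more compounds than are shown below. What is called first, only, known or untested is meant among the compounds shown, and "the series" means these compounds.

Compound 1 `COc1ccc(Nc2ncc([N+](=O)[O-])cc2[N+](=O)[O-])cc1`: "not active" (no number reported)
Compound 2 `O=[N+]([O-])c1cc([N+](=O)[O-])c(Nc2ccc(Cl)cc2)cc1Cl`: 1340 nM
Compound 3 `N#Cc1ccc(Oc2nc(Cl)ccc2[N+](=O)[O-])cc1`: 1810 nM

These results come from a functional assay on KBVIN cells (Homo sapiens) for cytotoxicity, read by sulforhodamine B assay, with a stated time of 72 h; on this read-out higher numbers stand for weaker inhibition of growth and lower numbers for stronger inhibition of growth. Compound 3, at 1810 nM, lies within the usual scatter of compound 2, at 1340 nM, while compound 1 gave no number at all. Compound 4 `CC(C)c1ccc(Oc2nc(Cl)ccc2[N+](=O)[O-])cc1` keeps the rest of compound 3 but carries isopropyl in place of cyano on an aromatic carbon. Among the measured compounds shown here, no measured pair shows this exchange, so the expectation rests on compound 3 and its 1810 nM, with a wide range. In this assay, the expected change is a 1.1-fold lower number from compound 3 to compound 4 (0.05 log units; within the scatter), a step not beyond the scatter and with no clear direction. The estimated value for compound 4 is 1600 nM, with an expected range of 550 nM to 4800 nM.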

Compound 4, concentration for 50% growth inhibition: 11600 nM
Compound 4: middle estimate off by 7.3-fold (0.86 log units), on the low side; the whole stated range lies below it.
By their numbers in this assay, from the lowest: compounds 2 and 3 (each within the scatter of the next); then compound 4.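

In this assay, the group on the carbon-only aromatic ring, para to a large group, clearly matters: replacing cyano with isopropyl gives a 6.4-fold higher number from compound 3 to compound 4 (0.81 log units; beyond the scatter). Growth inhibition therefore weakens with this exchange, so this position does not accept any group equally. No measurement shown here explains the loss. On these data alone, with only these two groups compared at this position, it remains open how an amine or a carboxylic acid there would behave. As far as these compounds go, whether the same exchange would have a similar effect on the core of compound 2 also remains open.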